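The source may hold more compounds than are shown below. What is called first, only, known or untested is meant among the compounds shown, and "the series" means these compounds.

Compound 3 `O=C(Nc1ccc(-n2ccccc2=O)cn1)[C@H]1C[C@](O)(c2ccccc2)CN1C(=O)Nc1ccc(Cl)cc1` gives 2.9 h in an in vivo ADME assay on the whole organism for metabolic stability, with Rattus norvegicus as the target, using cassette dosing (a higher number here means that the compound lasts longer, a lower number that the compound disappears faster), the highest of the three numbers recorded, though its gaps to compound 1 `CC[C@@]1(O)C[C@H](C(=O)Nc2ccc(-n3ccccc3=O)cc2F)N(C(=O)Nc2ccc(Cl)cc2)C1`, which gives 2.4 h, and to compound 2 `CC[C@@]1(OC)C[C@H](C(=O)Nc2ccc(-n3ccccc3=O)cc2F)N(C(=O)Nc2ccc(Cl)cc2)C1`, which gives 1.7 h, both lie within the scatter. Compound 4 `O=C(Nc1ccc(-n2ccccc2=O)cn1)[C@H]1C[C@](O)(c2ccccc2Cl)CN1C(=O)Nc1ccc(Cl)cc1` differs from compound 3 by chloro in place of hydrogen on an aromatic carbon. Among the compounds with values here, no measured step bears directly on this change: the only single-point step recorded, a 1.4-fold lower number from compound 1 to compound 2 (0.15 log units; within the scatter), concerns a methyl on an oxygen and fell within the scatter. Nothing among these three compounds indicates that a chloro on the phenyl moves this assay, so no step beyond the scatter is expected. Compound 4 is therefore expected to give 2.9 h, between 1.5 h and 5.5 h, an expected step of no change at the digits printed from compound 3 to compound 4 (within the scatter).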

Compound 4, half-life: 2.9 h
For compound 4 middle estimate and measured number coincide at the digits printed, and the stated range covers the measured number.
By their numbers in this assay, from the lowest: compounds 2, 1, 3 and 4 (each within the scatter of the next).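

In this assay, within the data shown here, the change from phenyl to 2-chlorophenyl gives no change at the digits printed from compound 3 to compound 4 (within the scatter) and is the only step read on this aromatic carbon, ortho to a large group. Here, then, a chloro can stand in place of hydrogen without a step beyond the scatter, which the earlier compounds could not show. Nothing measured accounts for this result, so it stays a bare observation. On these data alone, whether a methoxy, a nitrile or an amine at this place would behave the same remains open, as does a chloro elsewhere on the phenyl.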